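A few compounds are considered here, and "the series" means these few. Any claim that something is new, unique, unknown or untested is made for them only; others in the source may bear on it.

Compound 1 `CCC1=C(C(=O)OCC2CCCCC2)C(c2cccc(O)c2)NC(=O)N1` gives > 10000 nM in an ADME assay on CEMx174 cells (Homo sapiens) for cytotoxicity (on this read-out lower numbers stand for higher toxicity in this test and higher numbers for lower toxicity in this test), and this is a limit, not a number. Compound 2 `CCC1=C(C(=O)OCC2CCCCC2)C(c2cccc([N+](=O)[O-])c2)NC(=O)N1` gives > 10000 nM in this assay and this too is a limit. Compound 3 `CCC1=C(C(=O)OCC2CCCCC2)C(c2cccc(N)c2)NC(=O)N1` gives > 10000 nM in this assay and so it also stands at a limit. Among the measured compounds shown here, the whole series so far is described by the limit of > 10000 nM in this assay, at which 3 of the 3 values shown sit, with no number among the readings.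

Compound 4 `CCC1=C(C(=O)OCC2CCCCC2)C(c2ccc([N+](=O)[O-])cc2)NC(=O)N1` carries 4-nitrophenyl in place of 3-aminophenyl on a saturated ring carbon and keeps the shared core. For the measured compounds named here, three measured steps bear on this change: a step that the two limits leave unreadable from compound 1 to compound 2 and a step that the two limits leave unreadable from compound 1 to compound 3 and a step that the two limits leave unreadable from compound 2 to compound 3 and none of them has a size that can be carried over. Compound 2 also carries a nitro group and sits at the limit > 10000 nM in the same test. The expectation is therefore a step that the limit leaves unreadable from compound 3 to compound 4 in this assay with no step beyond the scatter and no clear direction. For compound 4 the estimated value is 15000 nM with an expected range from 8000 nM to 40000 nM in this test.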

Compound 4, half-maximal cytotoxic concentration: > 10000 nM
Compound 4 gave a limit, no number; the forecaster's own chance of this, stated with the estimate: 85%; the middle value lies beyond the limit too.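

Compound 4 joins compound 1, compound 2 and compound 3 at a limit in this assay, so no step among these compounds can be read: the limit of > 10000 nM in this assay, at which 4 of the 4 values shown sit.

The compounds shown leave open whether their aromatic groups differ at all in this assay.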